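The compounds below may be only part of what the source reports. "The series", "measured", "known", "first", "only" and "open" are said of these compounds alone.

Compound 1 `CC1=C(C(=O)Nc2ccc(Cl)cc2)C(c2ccccc2)C(C(=O)Nc2ccc(Cl)cc2)=C(C)N1` gives 15 ug/mL in an ADME assay on Vero cells (Chlorocebus sabaeus) for cytotoxicity, read by sulforhodamine B assay, with a stated time of 3 days; on this read-out higher numbers stand for lower toxicity in this test and lower numbers for higher toxicity in this test. Compound 2 `COc1ccc(C2C(C(=O)Nc3ccc(Cl)cc3)=C(C)NC(C)=C2C(=O)Nc2ccc(Cl)cc2)cc1` carries methoxy in place of hydrogen on an aromatic carbon, and in this assay compound 2 gives 20 ug/mL, which amounts to a 1.3-fold higher number from compound 1 to compound 2 (0.12 log units; within the scatter). Compound 3 `COc1ccc(NC(=O)C2=C(C)NC(=O)NC2c2ccccc2)cc1` is built on a different core, and how that core differs from the core of compound 1 is not broken down here. In this assay compound 3 gives 225 ug/mL, the highest of the three numbers. Compound 4 `COc1ccc(NC(=O)C2=C(C)NC(=O)NC2c2ccc(OC)cc2)cc1` differs from compound 3 by methoxy in place of hydrogen on an aromatic carbon, the same change already seen between compound 1 and compound 2. Because the earlier step of a 1.3-fold higher number from compound 1 to compound 2 (0.12 log units; within the scatter) stayed within the scatter, the step expected in this assay is also expected to be small: a 1.1-fold higher number from compound 3 to compound 4 (0.05 log units; within the scatter). Compound 4 is therefore estimated to give 250 ug/mL in this assay, with a likely range from 120 ug/mL to 500 ug/mL.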

Compound 4, half-maximal cytotoxic concentration: 158 ug/mL
Compound 4: middle estimate off by 1.6-fold (0.20 log units), on the high side; measured number inside the range.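

In this assay the methoxy group gives a 1.4-fold lower number from compound 3 to compound 4 (0.15 log units; within the scatter), so the second core also shows no step beyond the scatter. Set beside the earlier step, the change reads the same on both cores within the limits of the measurement: the same change on two cores in this assay, a 1.3-fold higher number (0.12 log units; within the scatter) from compound 1 to compound 2 and a 1.4-fold lower number (0.15 log units; within the scatter) from compound 3 to compound 4, 1.9-fold (0.28 log units) apart, within the scatter of two such steps. Going by these compounds alone, this suggests that phenyl to 4-methoxyphenyl can be carried between these two cores with no readable shift in this read-out, but it rests on only two pairs and does not show that the change would behave alike on any other core, nor does it give the opposite directions of the two steps any meaning.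

On these data alone, what an amine, a hydroxyl or a carboxylic acid would do in place of the methoxy stays open. So does the effect of a longer alkoxy chain there.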